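The source may hold more compounds than are shown below. What is called first, only, known or untested is meant among the compounds shown, and "the series" means these compounds.

Measured so far:
- compound 1, `COc1ccccc1NC(=O)CN1CCN(S(=O)(=O)N2CCC(C)CC2)CC1`: > 10000 nM in an assay on HEK293 cells for inhibition of potassium channel subfamily T member 1 (Homo sapiens), read by thallium flux; on this read-out higher numbers stand for weaker inhibition and lower numbers for stronger inhibition
- compound 2, `Cc1ccc(Cl)cc1NC(=O)CN1CCN(S(=O)(=O)N2CCC(C)CC2)CC1`: > 10000 nM

Compound 1 does not give a number in this assay; its value, > 10000 nM, is a limit of the measurement. Compound 2, carrying a 5-chloro-2-methylphenyl in place of the 2-methoxyphenyl on the amide-type nitrogen, likewise stops at a limit, > 10000 nM. Among the compounds with values here, the step that the two limits leave unreadable from compound 1 to compound 2 therefore has no readable size; the only evidence is the limit of > 10000 nM in this assay, at which 2 of the 2 values shown sit.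

Compound 3, `COc1ccc(C(F)(F)F)cc1NC(=O)CN1CCN(S(=O)(=O)N2CCC(C)CC2)CC1`, differs from compound 1 by trifluoromethyl in place of hydrogen on an aromatic carbon. Within the data shown here, no measured step touches this change, and the one step available cannot be sized, so nothing points to a stronger or weaker inhibitor. For compound 3 the expected step that the limit leaves unreadable from compound 1 to compound 3 is therefore of no size beyond the scatter, most likely ending again at a limit. Compound 3 is estimated at 15000 nM, within 3000 nM to 60000 nM.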

Compound 3, half-maximal inhibitory concentration: 2400 nM
The estimate for compound 3 lay 6.3-fold (0.80 log units) above the measured number; measured number outside the range, below it.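

Compound 3 is the only one of the three compounds shown that gives a number rather than a limit in this assay, which sets it apart from the others: the limit of > 10000 nM in this assay, at which 2 of the 3 values shown sit.

Placing trifluoromethyl on the aromatic carbon para to the methoxy group gives an at least 4.1-fold lower number from compound 1 to compound 3 (0.61 log units; beyond the scatter), so this position of the ring can carry a group of 4 heavy atoms and still yield stronger inhibition. This size is only a minimum, since the starting point is a limit and the real gap could be larger.

A single example cannot show whether the gain is specific to trifluoromethyl or whether another group at this carbon, such as a nitrile, an amine or a longer carbon chain, would serve as well. Going by these compounds, it also remains open whether trifluoromethyl would have the same result on a different carbon of this ring.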